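Aryl hydrazone variation on a shared diaryl ether core

The compounds below may be only part of what the source reports. "The series", "measured", "known", "first", "only" and "open" are said of these compounds alone.

Measured compounds:
- compound 1 `CN(C)CCn1cnnc1-c1cc(Oc2ccc(NC(=O)N/N=C/c3cccc(O)c3)cc2F)ccn1`: 780 nM
- compound 2 `CN(C)CCn1cnnc1-c1cc(Oc2ccc(NC(=O)N/N=C/c3ccc(F)cc3Cl)cc2F)ccn1`: 720 nM
- compound 3 `CN(C)CCn1cnnc1-c1cc(Oc2ccc(NC(=O)N/N=C/c3cc(Br)c(O)c(Br)c3)cc2F)ccn1`: 3760 nM

All three were read in a functional assay on NCI-H460 cells (Homo sapiens) for cytotoxicity, read by MTT assay, with a stated time of 72 h; on this read-out higher numbers stand for weaker inhibition and lower numbers for stronger inhibition. Compound 3 gives the highest number of the three; its nearest neighbour is compound 1 (a 4.8-fold higher number from compound 1 to compound 3 (0.68 log units; beyond the scatter)) and the furthest is compound 2 (a 5.2-fold higher number from compound 2 to compound 3 (0.72 log units; beyond the scatter)). The step from compound 1 to compound 2 stays within the scatter (a 1.1-fold lower number from compound 1 to compound 2 (0.03 log units; within the scatter)).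

Compound 4 `CN(C)CCn1cnnc1-c1cc(Oc2ccc(NC(=O)N/N=C/c3c(O)ccc4ccccc34)cc2F)ccn1` differs from compound 3 in one place: 2-hydroxynaphthalen-1-yl in place of 3,5-dibromo-4-hydroxyphenyl on a carbon with a double bond to nitrogen. Within the data shown here, no measured step places a 2-hydroxynaphthalen-1-yl group on this carbon, so the bearing steps are indirect. Both steps into compound 3 were modest rises, and both smaller aryl groups sat close together, so a return toward those lower numbers is expected but uncertain: a 2.5-fold lower number from compound 3 to compound 4 (0.40 log units; beyond the scatter). Compound 4 is estimated at 1500 nM, with a range from 500 nM to 5000 nM.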

Compound 4, half-maximal inhibitory concentration: 890 nM
The estimate for compound 4 lay 1.7-fold (0.23 log units) above the measured number, within the range that was stated.
By their numbers in this assay, from the lowest: compounds 2, 1 and 4 (each within the scatter of the next); then compound 3.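

The change to 2-hydroxynaphthalen-1-yl removes the rise seen with 3,5-dibromo-4-hydroxyphenyl (a 4.2-fold lower number from compound 3 to compound 4 (0.63 log units; beyond the scatter)), and the result stays level with the two smaller aryl groups (a 1.2-fold higher number from compound 2 to compound 4 (0.09 log units; within the scatter); a 1.1-fold higher number from compound 1 to compound 4 (0.06 log units; within the scatter)). This position therefore accepts a second six-membered aromatic ring without a shift beyond the scatter, and among these four compounds only compound 3, the one bromine-bearing member, stands apart.

As far as these compounds go, how a phenyl group carrying an amine or a carboxylic acid would read on this carbon remains open. No evidence is available on what lies behind these steps.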